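The source may hold more compounds than are shown below. What is called first, only, known or untested is meant among the compounds shown, and "the series" means these compounds.

Compound 1 `CCOC(=O)c1ccc(-c2noc(CO)n2)cc1` was tested in an ADME assay on MT2 cells (Homo sapiens) for cytotoxicity, read by XTT assay, with a stated time of 4 days (a higher number here means that more compound is tolerated, a lower number that less compound is tolerated), and gave 385000 nM, the highest of the two numbers measured; compound 2 `COc1ccc(N2C(=O)CSC2=S)cc1` gave 89600 nM, a lower number beyond the usual scatter. Compound 3 `O=C(O)c1ccc(-c2noc(CO)n2)cc1` has not yet been measured. It differs from compound 1 in one place (hydrogen in place of ethyl on an oxygen next to a carbonyl group), on an oxygen next to a carbonyl group. Among the measured compounds shown here, no step of this kind has been measured here, so the expectation rests on compound 1 alone, whose 385000 nM already lies high; the step of a 1.2-fold higher number from compound 1 to compound 3 (0.07 log units; within the scatter) is expected to be small, if anything towards a higher number. Compound 3 is estimated at 450000 nM, within 200000 nM to 1000000 nM.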

Compound 3, half-maximal cytotoxic concentration: 455000 nM
Compound 3: middle estimate off by 1.0-fold (0.00 log units), on the low side, and the stated range covers the measured number.
By their numbers in this assay, from the lowest: compound 2; then compounds 1 and 3 (each within the scatter of the next).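

In this assay, the change from ethoxycarbonyl to carboxy gives the step of a 1.2-fold higher number from compound 1 to compound 3 (0.07 log units; within the scatter), so removing the ethyl from this oxygen next to a carbonyl group leaves the tolerated concentration within the scatter. At this position, then, the ethyl can give way to hydrogen without a measurable difference in this read-out. No measurement shown here explains this result.

As far as these compounds go, whether a propyl or benzyl group on that oxygen, or an amine in place of the ethoxy, would also stay within the scatter of compound 1 remains open. From the compounds shown here alone, whether the same exchange would read alike on another core also remains open.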